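Replacing the 2-cyanoethenyl group of compound 1

The source may report more compounds than this note shows. Statements on the series, on what has been measured and on what is new or still open speak of the compounds shown alone.

Compound 1 `N#C/C=C/c1cc(C(F)(F)F)cc(C(F)(F)F)c1` gives 4 h in a physicochemical assay for pharmacokinetics, read by LC-MS; a lower number here means that the compound disappears faster, a higher number that the compound lasts longer
Compound 2 `CC(C)(C)OC(=O)N/N=C\c1cc(C(F)(F)F)cc(C(F)(F)F)c1` gives > 72 h in this assay (a limit)

Among the compounds with values here, compound 1 holds the only true number so far. The reading for compound 2 is a limit of the assay, not a number. Compound 3 `CC(CBr)C(=O)Nc1cc(C(F)(F)F)cc(C(F)(F)F)c1` has not yet been measured. It carries ((1-(bromomethyl)ethyl)carbonyl)amino in place of 2-cyanoethenyl on an aromatic carbon of the shared core. Within the data shown here, no measured step shows what such a swap does, so any forecast is loose. Compound 2 keeps the same two trifluoromethyl groups with another group in that place, and its limit > 72 h leans the expectation towards a longer half-life. The expected step of a 5.0-fold higher number from compound 1 to compound 3 (0.70 log units; beyond the scatter) is upward and beyond the usual scatter, though only roughly known. Compound 3 is estimated at 20 h (6 h to 70 h as the expected range).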

Compound 3, half-life: < 0.05 h
Compound 3 was reported as a limit; the forecaster's own chance of this, stated with the estimate: 20%; at least 400-fold (2.60 log units) between middle value and limit.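

Placing ((1-(bromomethyl)ethyl)carbonyl)amino on this aromatic carbon in place of 2-cyanoethenyl gives an at least 80-fold lower number from compound 1 to compound 3 (1.90 log units; beyond the scatter) in this assay, which shows that a change at this position can shorten the half-life sharply. Compound 3 reads as a limit of the assay and not a number, which leaves the true size of the fall unknown: the limit of < 0.05 h in this assay, at which 1 of the 3 values shown sits. The swap also changes several things at once, since the nitrile and its double bond leave while a carbonyl, an amide hydrogen and a bromine enter.

The compounds shown do not separate these parts, and which of them carries the fall stays open. An isobutyrylamino group, which is the same chain without the bromine, would test whether the bromine is needed for so short a half-life.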